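Chloro-to-hydrogen change on a fused bicyclic core

The source may hold more compounds than are shown below. What is called first, only, known or untested is meant among the compounds shown, and "the series" means these compounds.

Measured compounds in a functional assay on SK-MEL-5 cells (Homo sapiens) for cytotoxicity, read by sulforhodamine B assay, with a stated time of 48 h; on this read-out lower numbers stand for higher toxicity in this test and higher numbers for lower toxicity in this test:
compound 1, `ClCc1ccc(Cn2cnc3c(Cl)ncnc32)cc1`, gives 74100 nM.
compound 2, `ClCc1ccc(Cn2cnc3nc(Cl)nc(Cl)c32)cc1`, gives 31600 nM.
compound 3, `ClCc1ccc(Cn2cnc3c(Cl)nc(Cl)nc32)cc1`, gives 44700 nM.

The three measured compounds share a benzyl group carrying a chloromethyl substituent, attached to a fused two-ring aromatic core that differs in how many chloro groups it bears and where they sit. Compound 2 has the lowest number of the three in this assay, but its gap to compound 3 lies within the scatter, so no order between those two can be drawn; only against compound 1 does compound 2 stand apart. The difference between the cores of compound 2 and compound 3 is not broken down here.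

One change is seen once among the measured compounds: from compound 3 to compound 1, (hydrogen in place of chloro on an aromatic carbon). That step, a 1.7-fold higher number from compound 3 to compound 1 (0.22 log units; within the scatter), lies within the scatter.

Compound 4, `ClCc1ccc(Cn2cnc3ncnc(Cl)c32)cc1`, has not been measured. It differs from compound 2 by the same change, (hydrogen in place of chloro on an aromatic carbon), at a place described in the same words as for the step from compound 3 to compound 1. On that single precedent, the step from compound 2 to compound 4 is expected to be a 1.6-fold higher number from compound 2 to compound 4 (0.22 log units; within the scatter), a modest rise of the number, because the earlier step of a 1.7-fold higher number from compound 3 to compound 1 (0.22 log units; within the scatter) was of that size. Compound 4 is therefore estimated at 52000 nM, with a range from 25000 nM to 105000 nM.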

Compound 4, concentration lethal to 50% of the cells: 34700 nM
Compound 4: middle estimate off by 1.5-fold (0.18 log units), on the high side, and the stated range covers the measured number.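

In this assay, hydrogen in place of chloro on an aromatic carbon, here between two ring nitrogen atoms, gives a 1.1-fold higher number from compound 2 to compound 4 (0.04 log units; within the scatter), so compound 2 and compound 4 cannot be put in any order. Set beside the earlier case, the new step cannot be told apart from it: the same change on two cores in this assay, a 1.7-fold higher number (0.22 log units; within the scatter) from compound 3 to compound 1 and a 1.1-fold higher number (0.04 log units; within the scatter) from compound 2 to compound 4, 1.5-fold (0.18 log units) apart, within the scatter of two such steps This shows that the change, carried from one core to the other, gave a step within the scatter both times, with nothing to separate the two cores on this count, but it does not show that the change is without any effect, and two pairs say nothing about how it would behave on a further core.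

Every compound shown keeps the same benzyl group with its chloromethyl substituent, and the cores carry only chloro or hydrogen, so the effect of any other group on the core, such as an amine or a methoxy group in place of chloro, stays open. Equally open, on these data alone, is what this assay would read if the chloromethyl group gave way to a longer chain or a hydroxymethyl group, which would test whether that shared group matters to these numbers at all.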